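The compounds below may be only part of what the source reports. "The series", "measured", "known", "first", "only" and "open" are said of these compounds alone.

compound 1 `CC1CC/C(=N\Nc2ccccc2I)c2ncc(C(=O)O)c(=O)n21` — > 1000 umol/kg
compound 2 `CCOc1ccccc1N/N=C1\CCC(C)n2c1ncc(C(=O)O)c2=O` — > 1000 umol/kg

Both measured values are limits of a functional assay on the whole organism for inhibition, with Rattus norvegicus as the target (on this read-out higher numbers stand for an effect only at larger amounts of compound and lower numbers for an effect already at smaller amounts), not numbers. In this assay compound 1 gives only the limit > 1000 umol/kg. Compound 2 likewise gives only the limit > 1000 umol/kg. Among the compounds with values here, the single measured step, a step that the two limits leave unreadable from compound 1 to compound 2, therefore cannot be read, and all that the values show is the limit of > 1000 umol/kg in this assay, at which 2 of the 2 values shown sit. Compound 3 `Cc1ccc(N/N=C2\CCC(C)n3c2ncc(C(=O)O)c3=O)cc1` differs from compound 1 by 4-methylphenyl in place of 2-iodophenyl on an amine nitrogen. Within the data shown here, no measured step bears on this change, so no direction can be taken from the data. Compound 3 is expected to give 1500 umol/kg, between 800 umol/kg and 5000 umol/kg, most likely again as a limit. The expected step is a step that the limit leaves unreadable from compound 1 to compound 3.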

Compound 3, dose for 50% inhibition: > 1000 umol/kg
Compound 3: no number, only a limit; the forecaster's own chance of this, stated with the estimate: 80%; the middle value lies beyond the limit too.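

In this assay compound 3, like compound 1, gives only a limit, so the step from compound 1 to compound 3 cannot be read. As far as these compounds go, whether the group on the amine nitrogen changes the effect in this assay at all stays open.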